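Branching the Pentyl Chain: Isopentyl to Pentan-3-yl

This account rests on a few compounds, and the source may have more. Where it says the series, first, only, none or still open, it means among the compounds named here.

Of the compounds shown here, two with a shared core have been measured. Compound 1 `CCCCCc1nc2c([nH]1)N1C(=N[C@@H]3CCC[C@@H]31)N(C)C2=O` carries a straight pentyl chain and in an assay on isolated protein for inhibition of dual specificity calcium/calmodulin-dependent 3',5'-cyclic nucleotide phosphodiesterase 1A (Bos taurus) (a higher number here means a weaker inhibitor, a lower number a stronger inhibitor), compound 1 gives 31 nM. Compound 2 `CC(C)CCc1nc2c([nH]1)N1C(=N[C@@H]3CCC[C@@H]31)N(C)C2=O` carries an isopentyl chain and in this assay compound 2 gives 14 nM. Among the measured compounds shown here, the single measured step, a 2.2-fold lower number from compound 1 to compound 2 (0.35 log units; beyond the scatter), is the only guide available. On these two numbers compound 2 stands lowest, with compound 1 as its nearest neighbour at that modest, beyond-scatter distance.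

Compound 3 `CCC(CC)c1nc2c([nH]1)N1C(=N[C@@H]3CCC[C@@H]31)N(C)C2=O` differs from compound 2 by pentan-3-yl in place of isopentyl on an aromatic carbon, the same atoms joined differently. The step of a 2.2-fold lower number from compound 1 to compound 2 (0.35 log units; beyond the scatter) bears on this change only loosely, since it concerned branching at a different point of the chain; it showed that rearranging the five carbons shifts the number only modestly. The step from compound 2 to compound 3 is therefore expected to be small, likely within the scatter, as a 1.6-fold higher number from compound 2 to compound 3 (0.20 log units; within the scatter), with some chance of a weaker result. Compound 3 is estimated at 22 nM in this assay, within a range from 7 nM to 70 nM.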

Compound 3, half-maximal inhibitory concentration: 150 nM
Compound 3: middle estimate off by 6.8-fold (0.83 log units), on the low side; the whole stated range lies below it.
By their numbers in this assay, from the lowest: compound 2; then compound 1; then compound 3.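

Among the compounds shown here, the position on the aromatic carbon between two ring nitrogen atoms proves far more sensitive to how the same atoms are joined than the earlier compounds suggested: pentan-3-yl in place of isopentyl gives an 11-fold higher number from compound 2 to compound 3 (1.03 log units; beyond the scatter) in this assay, a large step where the earlier change from pentyl to isopentyl was only modest. Measured against the straight chain, pentan-3-yl also moves the number the opposite way from isopentyl, with a 4.8-fold higher number from compound 1 to compound 3 (0.68 log units; beyond the scatter), so across these three compounds branching alone does not set the direction of the change: isopentyl gives a lower number than pentyl, and pentan-3-yl a higher one. Nothing in the available data gives a reason for this difference between the two branched chains.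

The compounds shown leave open whether the higher number is peculiar to pentan-3-yl or would also appear with other groups at this position, such as isopropyl, tert-butyl or cyclopentyl. They also leave open how a longer straight chain such as hexyl, or a chain ending in an amine, would compare with isopentyl.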